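The source may report more compounds than this note shows. Statements on the series, on what has been measured and on what is new or still open speak of the compounds shown alone.

Measured in a functional assay on HeLa cells (Homo sapiens) for antiproliferative activity, read by MTT assay, with a stated time of 24 h; on this read-out higher numbers stand for weaker inhibition and lower numbers for stronger inhibition:
- compound 1 `Cc1ccc(-c2nn(-c3ccccc3)cc2-c2nc3ccccc3n2S(=O)(=O)c2ccc(C)cc2)cc1`: 480 nM
- compound 2 `Cc1ccc(-c2nn(-c3ccccc3)cc2-c2nc3ccccc3n2S(=O)(=O)c2cc(C)ccc2C)cc1`: 370 nM
- compound 3 `Cc1ccc(-c2nn(-c3ccccc3)cc2-c2nc3ccccc3n2S(=O)(=O)c2ccc(F)cc2)cc1`: 3670 nM

Compound 3 has the highest number of the three, which makes it the weakest inhibitor in this set. Compound 4 `Cc1ccc(-c2nn(-c3ccccc3)cc2-c2nc3ccccc3n2S(=O)(=O)c2ccc(C(F)(F)F)cc2)cc1` differs from it at one place, with trifluoromethyl in place of fluoro on an aromatic carbon, para to a large group (trifluoromethyl in place of fluoro on an aromatic carbon).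

For the measured compounds named here, no measured compound carries trifluoromethyl, so the evidence is indirect. The closest guide is a 7.6-fold higher number from compound 1 to compound 3 (0.88 log units; beyond the scatter), where fluoro took the place of methyl. The step of a 9.9-fold higher number from compound 2 to compound 3 (1.00 log units; beyond the scatter), with 4-fluorophenyl in place of 2,5-dimethylphenyl, points the same way. The step of a 1.3-fold lower number from compound 1 to compound 2 (0.11 log units; within the scatter) involves no fluoro group and offers little guidance. Trifluoromethyl, like methyl, is attached through carbon, but it also contains fluorine, so only a partial return toward the lower numbers is expected, and the direction remains uncertain. The expected result is a 2.4-fold lower number from compound 3 to compound 4 (0.39 log units; beyond the scatter). For compound 4, the estimated value in this assay is 1500 nM, with an expected range of 450 nM to 4500 nM.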

Compound 4, half-maximal inhibitory concentration: 1520 nM
Compound 4: middle estimate off by 1.0-fold (0.01 log units), on the low side; low and high end bracket the measured number.
By their numbers in this assay, from the lowest: compounds 2 and 1 (each within the scatter of the next); then compound 4; then compound 3.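

In this assay, putting trifluoromethyl in place of fluoro on this aromatic carbon, para to a large group, brings back part of the activity seen with methyl, with a 2.4-fold lower number from compound 3 to compound 4 (0.38 log units; beyond the scatter) as the measured step. The recovery is only partial: there is still a 3.2-fold higher number from compound 1 to compound 4 (0.50 log units; beyond the scatter) in the comparison with the methyl compound and a 4.1-fold higher number from compound 2 to compound 4 (0.61 log units; beyond the scatter) in the comparison with the 2,5-dimethylphenyl compound, so methyl, trifluoromethyl and fluoro now stand at three separate levels at this position. Nothing measured here explains why the groups fall in this order.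

As far as these compounds go, it remains open whether an ethyl or a methoxy group at this carbon would track methyl or trifluoromethyl. How an amine or a carboxylic acid would fare here is also unknown.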